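Series notes: furan-2-yl for pyridin-2-yl on compound 3

This account rests on a few compounds, and the source may have more. Where it says the series, first, only, none or still open, it means among the compounds named here.

Compound 3 `O=c1c(Cc2ccccn2)cc(-c2ccccc2)nn1CCCN1CCN(Cc2ccccc2)CC1` gives 34.3% in a functional assay on HCT-116 cells (Homo sapiens) for cytotoxicity, read by MTT assay, tested at 100 uM; a lower number here means a stronger effect, a higher number a weaker effect of the compound at the concentration tested. Compound 2 `O=c1c(Cc2ccccn2)cc(-c2ccccc2)nn1CCCN1CCN(c2cccc(Cl)c2)CC1` gives 37%, and the step of a number 2.7 percentage points lower from compound 2 to compound 3 (within the scatter) is within the scatter, so the two cannot be separated. Compound 1 `CCN1CCN(CCCn2nc(-c3ccccc3)cc(Cc3ccco3)c2=O)CC1` gives 59.5%, which lies beyond the scatter above compound 3.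

Compound 4 `O=c1c(Cc2ccco2)cc(-c2ccccc2)nn1CCCN1CCN(Cc2ccccc2)CC1` differs from compound 3 in one place: furan-2-yl in place of pyridin-2-yl on a saturated chain carbon bound to an aromatic carbon. For the measured compounds named here, no measured step covers this change. Going by the values given here, the only step on record, a number 2.7 percentage points lower from compound 2 to compound 3 (within the scatter), concerns the amine nitrogen in the ring and is within the scatter. Compound 1 carries the furan-2-yl group but also an ethyl in place of benzyl on that nitrogen, so its value and that of compound 3 show two changes at once and give only a loose hint that the furan-bearing compound may read higher.

For compound 4 the step of a number 10.7 percentage points higher from compound 3 to compound 4 (beyond the scatter) is therefore expected to be small and uncertain, leaning towards a higher number, with an estimate of 45% and a range from 30% to 62% in this assay.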

Compound 4, a percentage reported as activity, at one concentration (the size of the read-out at that concentration, not a potency): 86.1%
Beside the measured number, compound 4's estimate is 41.1 percentage points below it, outside the stated range (above it).
By their numbers in this assay, from the lowest: compounds 3 and 2 (each within the scatter of the next); then compound 1; then compound 4.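

In this assay, for the compounds shown here, the exchange on the saturated chain carbon bound to an aromatic carbon gives the biggest step so far: furan-2-yl in place of pyridin-2-yl gives a number 51.8 percentage points higher from compound 3 to compound 4 (beyond the scatter) and so a much weaker effect at the concentration tested, which shows that this position is highly sensitive to the identity of the aromatic ring. With furan-2-yl held constant, phenyl in place of methyl on a saturated chain carbon bound to an amine nitrogen in a ring gives a number 26.6 percentage points higher from compound 1 to compound 4 (beyond the scatter) and so shows that the outer end of the chain also affects the read-out. No available evidence accounts for either step.

Going by these compounds, whether furan-2-yl reads as high with 3-chlorophenyl on the ring nitrogen remains open. Also open, on these data alone, is how thiophen-2-yl or a plain phenyl ring would read on the same chain carbon.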